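The source may hold more compounds than are shown below. What is called first, only, known or untested is meant among the compounds shown, and "the series" means these compounds.

Working notes on the series. Compound 1 `CC(=O)c1cc(-c2ccccc2)cc2cc(-c3ccccc3)[nH]c12` in a functional assay on HeLa cells (Homo sapiens) for cytotoxicity, read by MTT assay, with a stated time of 2 days, tested at 100 uM (a higher number here means a weaker effect of the compound at the concentration tested, a lower number a stronger effect), gives 51.4%. Within the data shown here, compound 2 `CC(=O)c1cc(-c2ccc(F)cc2)cc2cc(-c3ccccc3)[nH]c12` in this assay gives 24.8%, the lowest of the two numbers so far; the only measured step, a number 26.6 percentage points lower from compound 1 to compound 2 (beyond the scatter), put it there. Compound 3 `COc1ccc(-c2cc3cc(-c4ccc(F)cc4)cc(C(C)=O)c3[nH]2)cc1` is not yet measured in this assay. It differs from compound 2 as follows: methoxy in place of hydrogen on an aromatic carbon. Cut one bond further out, the same difference reads phenyl to 4-methoxyphenyl. Among the measured compounds shown here, no measured step changes a hydrogen on this particular ring, so nothing bears directly on the change; the one step available, a number 26.6 percentage points lower from compound 1 to compound 2 (beyond the scatter), only shows that a single substituent on a pendant phenyl can move the number by a modest amount. For the measured compounds named here, with no direct precedent, a step of no clear direction is expected, and for compound 3 the estimate in this assay is 30%, between 10% and 55%, meaning an expected step of a number 5.2 percentage points higher from compound 2 to compound 3 (within the scatter).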

Compound 3, a percentage reported as activity, at one concentration (the size of the read-out at that concentration, not a potency): 46.5%
For compound 3 the middle estimate is 16.5 percentage points below the measured one; measured number inside the range.
By their numbers in this assay, from the lowest: compound 2; then compounds 3 and 1 (each within the scatter of the next).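

In this assay, the phenyl that becomes 4-methoxyphenyl also responds to substitution: methoxy in place of hydrogen on an aromatic carbon, para to a large group, gives a number 21.7 percentage points higher from compound 2 to compound 3 (beyond the scatter). This moves the number towards a weaker effect at the concentration tested, whereas the fluoro change on the other phenyl gave a number 26.6 percentage points lower from compound 1 to compound 2 (beyond the scatter), so single substituents on these two rings are now seen to move the number in opposite directions. Nothing available bears on why the methoxy step goes this way.

The compounds shown leave open whether this step belongs to methoxy alone or would also appear with another group there, such as an amine, a hydroxyl or a longer ethoxy chain. They also leave open whether methoxy gives a step of this size without the fluoro on the other phenyl.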